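This account rests on a few compounds, and the source may have more. Where it says the series, first, only, none or still open, it means among the compounds named here.

Compound 2 `O=C(Nc1cc(C(F)(F)F)cc(C(F)(F)F)c1)c1ccc(Cl)cc1O` was run in a functional assay on Jurkat cells (Homo sapiens) for cytotoxicity, read by luminescence and CellTiter-Glo, with a stated time of 3 days (a lower number here means a stronger inhibitor, a higher number a weaker inhibitor), and there compound 2 gives 570 nM. Among the compounds with values here, of the three numbers measured so far, compound 2 stands second highest. Compound 1 `O=C(Nc1ccc(C(F)(F)F)cc1)c1cc(Br)ccc1O` gives 620 nM in this assay, a number within the scatter of compound 2, so the two cannot be ordered. Compound 3 `Cc1cc(C#N)ccc1NC(=O)c1ccc2cccnc2c1O` gives 270 nM in this assay, and the gap between compound 3 and compound 2 lies beyond the scatter. Compound 4 `O=C(Nc1cc(C(F)(F)F)cc(C(F)(F)F)c1)c1ccc(Br)cc1O` has not yet been measured. It differs from compound 2 in one place: bromo in place of chloro on an aromatic carbon. Within the data shown here, no pair of measured compounds isolates this change, so the data give no direct reading of its size. Compound 1 also carries a bromo group on its core, with the rest of the structure different, and its number sits close to that of compound 2. The expected step is therefore a 1.3-fold lower number from compound 2 to compound 4 (0.10 log units; within the scatter), a small shift that is not expected to reach beyond the scatter, downward if anything. Compound 4 is estimated at 450 nM, with a range from 200 nM to 1000 nM.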

Compound 4, half-maximal inhibitory concentration: 930 nM
Beside the measured number, compound 4's estimate is 2.1-fold (0.32 log units) below it; measured number inside the range.
By their numbers in this assay, from the lowest: compound 3; then compounds 2, 1 and 4 (each within the scatter of the next).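

The pair gives a direct reading of bromo in place of chloro at this position, meta to a hydroxy group and para to a large group: in this assay the exchange shows a 1.6-fold higher number from compound 2 to compound 4 (0.21 log units; within the scatter). Compound 2 and compound 4 therefore cannot be ordered, and on this core the two halogens are not told apart by this read-out. Nothing available bears on the reason for this result.

The compounds shown leave open whether a different group at this position, such as fluoro, methoxy or an amine, or a plain hydrogen, would give a number beyond the scatter of these two. They also leave open whether the same exchange reads alike with the different rest of the structure seen in compound 1.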